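The compounds below may be only part of what the source reports. "The series", "measured", "known", "first", "only" and "open" are said of these compounds alone.

Compounds measured in an assay on LtK cells with ATP-sensitive inward rectifier potassium channel 11 (Homo sapiens) as the target; a lower number here means that less compound is needed, a higher number that more compound is needed for the effect:
compound 1, `CCCC(=O)Nc1c(C(O)(C(F)(F)F)C(F)(F)F)ccc2ccccc12`, 131 nM
compound 2, `O=C(Nc1c(C(O)(C(F)(F)F)C(F)(F)F)ccc2ccccc12)c1ccccc1`, 44 nM
compound 3, `Cc1ccccc1C(=O)Nc1c(C(O)(C(F)(F)F)C(F)(F)F)ccc2ccccc12`, 5550 nM

Compound 3 stands highest of the three, needing the most compound: a 42-fold higher number from compound 1 to compound 3 (1.63 log units; beyond the scatter) and a 130-fold higher number from compound 2 to compound 3 (2.10 log units; beyond the scatter). Compound 4, `O=C(Nc1c(C(O)(C(F)(F)F)C(F)(F)F)ccc2ccccc12)c1ccc(Br)cc1`, is the next member, differing by 4-bromophenyl in place of 2-methylphenyl on a carbonyl carbon. Among the compounds with values here, two measured steps bear on this. The step of a 130-fold higher number from compound 2 to compound 3 (2.10 log units; beyond the scatter) shows that the methyl on the aromatic carbon accounts for most of what separates compound 3 from compound 2; compound 4 lacks that methyl. Within the data shown here, no measured compound carries bromine, so the effect of the entering 4-bromophenyl is not known from these data. A large step toward a lower number is therefore expected, a 46-fold lower number from compound 3 to compound 4 (1.67 log units; beyond the scatter), with compound 4 landing nearer compound 2 and compound 1 than compound 3. Compound 4 is estimated at 120 nM, in the range 20 nM to 900 nM.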

Compound 4, half-maximal effective concentration: 47 nM
Compound 4: middle estimate off by 2.6-fold (0.41 log units), on the high side, within the range that was stated.
By their numbers in this assay, from the lowest: compounds 2 and 4 (each within the scatter of the next); then compound 1; then compound 3.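

In this assay, a substituent on the aromatic ring of the benzoyl-type amide does not by itself carry the penalty seen with 2-methylphenyl: 4-bromophenyl in its place gives a 120-fold lower number from compound 3 to compound 4 (2.07 log units; beyond the scatter), and against plain phenyl the same group gives a 1.1-fold higher number from compound 2 to compound 4 (0.03 log units; within the scatter). Against the propyl amide, 4-bromophenyl gives a 2.8-fold lower number from compound 1 to compound 4 (0.45 log units; beyond the scatter), matching the modest gain already seen with phenyl. Nothing available explains the gap between the two substituted rings. What 2-bromophenyl or 4-methylphenyl on the same carbonyl carbon would give stays open, so the compounds shown do not separate the substituent from its place on the ring.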